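Changing the Aryl Group: What to Expect for Compound 4

This account rests on a few compounds, and the source may have more. Where it says the series, first, only, none or still open, it means among the compounds named here.

For the measured compounds named here, compound 3 `CCc1ccccc1-n1nncc1CN1C(=O)C2(C(C#N)=C(N)Oc3c(N)cc4nc5ccccc5nc4c32)c2ccccc21` is one of three compounds measured in a functional assay on A549 cells (Homo sapiens) for antiproliferative activity, read by MTT assay, with a stated time of 48 h (a higher number here means a weaker inhibitor, a lower number a stronger inhibitor), where compound 3 gives 24600 nM. That is the lowest of the three numbers, but the gaps to the other two lie within the scatter, so no order among them can be read. Compound 2 `N#CC1=C(N)Oc2c(c3nc4ccccc4nc3c3ccccc23)C12C(=O)N(Cc1cnnn1-c1cccc(Cl)c1)c1ccccc12` gives 32600 nM, and compound 1 `Cc1cccc(-n2nncc2CN2C(=O)C3(C(C#N)=C(N)Oc4c3c3nc5ccccc5nc3c3ccccc43)c3ccccc32)c1` gives 39600 nM. Going by the values given here, the only measured step that changes a single place, a 1.2-fold lower number from compound 1 to compound 2 (0.08 log units; within the scatter), swaps one small group on an aromatic carbon and leaves the number essentially where it was.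

Compound 4 `Cc1ccc(-n2nncc2CN2C(=O)C3(C(C#N)=C(N)Oc4c(N)cc5nc6ccccc6nc5c43)c3ccccc32)cc1C` differs from compound 3 in one place: 3,4-dimethylphenyl in place of 2-ethylphenyl on an aromatic nitrogen. Among the compounds with values here, no measured step covers this kind of swap, and the one step that was measured was within the scatter. Compound 3 itself differs from compound 1 and compound 2 in more than one place, so its value cannot be tied to the aryl group alone. With the two groups being of the same size and make-up, the expected step is a 1.0-fold higher number from compound 3 to compound 4 (0.01 log units; within the scatter), meaning no change beyond the scatter is anticipated.

Compound 4 is therefore estimated at 25000 nM, with a range from 12000 nM to 50000 nM.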

Compound 4, half-maximal inhibitory concentration: > 50000 nM
Compound 4 was reported as a limit (the forecaster's own chance of this, stated with the estimate: 5%); middle value at least 2.0-fold (0.30 log units) from the limit.
By their numbers in this assay, from the lowest: compounds 3, 2 and 1 (each within the scatter of the next). At a limit, above all of these: compound 4.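

The result for compound 4 in this assay is a limit and not a number: the limit of > 50000 nM in this assay, at which 1 of the 4 values shown sits. For the compounds shown here, it gives the first step at this aryl position on the triazole-free wording of the data, an at least 2.0-fold higher number from compound 3 to compound 4 (0.30 log units; that floor lies within the scatter), and only its floor is known, so the true gap could be as small as the scatter or much larger. Even so, two aryl groups with the same count of carbon atoms and the same ring now stand apart in one respect: compound 3 has a measured number, while compound 4 falls outside the range that gives one, something the small swap on an aromatic carbon between compound 1 and compound 2 gave no sign of.

The compounds shown cannot separate the loss of the 2-ethylphenyl group from the arrival of the 3,4-dimethylphenyl group, and a true number for compound 4 remains unknown. As far as these compounds go, it also stays open how this position would read with an aryl group carrying an amine or a carboxylic acid, or with a longer chain in place of the ethyl.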